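Amine substituent change from compound 2 to compound 3

This account rests on a few compounds, and the source may have more. Where it says the series, first, only, none or still open, it means among the compounds named here.

Measured in an assay on AV12 cells for binding affinity to Neuropeptide Y receptor type 1 (Homo sapiens) (on this read-out lower numbers stand for stronger inhibition and higher numbers for weaker inhibition), so far:
compound 1 `Cc1cccc2c1nc(COc1ccc(Cl)cc1)n2CCCC1CCN(C)CC1`: 52 nM
compound 2 `CCCN1CCC(CCCn2c(COc3ccc(Cl)cc3)nc3c(C)cccc32)CC1`: 29 nM

Going by the values given here, compound 2 shows the lowest of the two numbers in this assay; its only neighbour is compound 1, and the step of a 1.8-fold lower number from compound 1 to compound 2 (0.25 log units; within the scatter) stays within the scatter, so the two compounds cannot be ordered against each other on this read-out.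

Compound 3 `Cc1cccc2c1nc(COc1ccc(Cl)cc1)n2CCCC1CCN(Cc2ccccc2)CC1` is not yet measured. It differs from compound 2 by phenyl in place of ethyl on a saturated chain carbon bound to an amine nitrogen in a ring, or, cut one bond further out, propyl to benzyl.

Among the compounds with values here, the only measured step that touches the same position is a 1.8-fold lower number from compound 1 to compound 2 (0.25 log units; within the scatter), a small gain from a hydrogen to an ethyl group that does not rise beyond the scatter. Nothing measured speaks to a phenyl at this position, so the direction of the step is open. The expectation is therefore a step of modest size, a 1.2-fold lower number from compound 2 to compound 3 (0.06 log units; within the scatter), which may well lie within the scatter.

Compound 3 is estimated at 25 nM in this assay, with a range of 8 nM to 80 nM.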

Compound 3, inhibition constant: 109 nM
Beside the measured number, compound 3's estimate is 4.4-fold (0.64 log units) below it; the whole stated range lies below it.
By their numbers in this assay, from the lowest: compounds 2 and 1 (each within the scatter of the next); then compound 3.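

In this assay, this position does not tolerate every group alike: propyl to benzyl gives a 3.8-fold higher number from compound 2 to compound 3 (0.58 log units; beyond the scatter), whereas the change from hydrogen to ethyl stayed within the scatter. Measured against the hydrogen compound as well, phenyl in place of hydrogen gives a 2.1-fold higher number from compound 1 to compound 3 (0.32 log units; beyond the scatter), so compound 3 stands apart from both compound 1 and compound 2, although those two cannot be ordered against each other. The series therefore shows a modest but readable penalty for the phenyl, whichever of the two smaller groups serves as the reference, and nothing measured here explains it.

Three compounds cannot show whether the higher number goes with the aromatic ring itself or simply with the larger count of carbons on this chain carbon. A cyclohexylmethyl group or a longer open chain such as pentyl would separate those two readings, and a phenethyl group or a benzyl carrying a hydroxyl would show whether an aromatic ring can be kept at this position at all without the same rise.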